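Acetyl for Hydrogen on a Fluorinated Benzoic Acid

The source may report more compounds than this note shows. Statements on the series, on what has been measured and on what is new or still open speak of the compounds shown alone.

Compound 1 `COc1c(F)c(F)c(F)c(F)c1C(=O)O` and compound 2 `O=C(O)c1c(O)c(F)cc(F)c1F` were both tested in a functional assay on the whole organism for inhibition, with Rattus norvegicus as the target, read by paw edema, with stated times of 30 min and 3 h, at a dose of 25 mg/kg by the intraperitoneal route; a higher number here means more inhibition at the dose given (going by the name of the read-out), a lower number less inhibition. In this assay compound 1 gives 53.8%, and compound 2 gives 47%. Among the compounds with values here, compound 2 holds the lower of the two numbers, with compound 1 its only neighbour, and the gap between them lies within the usual scatter of this measurement, so no order can be read from it. Compound 3 `CC(=O)Oc1c(F)cc(F)c(F)c1C(=O)O` differs from compound 2 in one place: acetyl in place of hydrogen on an oxygen on an aromatic ring. The same difference, cut one bond further out, reads hydroxy to acetoxy. Within the data shown here, no step between measured compounds that differ in a single place is available, so this change has no precedent in this assay; a shift beyond the scatter in either direction is not expected. Compound 3 is therefore estimated to give 47% in this assay, with a range from 30% to 62%. The step this estimate means, no change at the digits printed from compound 2 to compound 3 (within the scatter), is expected to stay within the scatter.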

Compound 3, a percentage reported as inhibition, in the whole organism at one dose (the size of the read-out at that dose, not a potency): 37.3%
Estimate against measurement, compound 3: 9.7 percentage points above; the range from low to high includes it.
By their numbers in this assay, from the lowest: compounds 3, 2 and 1 (each within the scatter of the next, the first and the last beyond it).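

In this assay, the oxygen on the aromatic ring now has its first single-place step: acetyl in place of hydrogen gives a number 9.7 percentage points lower from compound 2 to compound 3 (within the scatter). The hydroxy group of compound 2 can therefore be replaced by acetoxy without the reading moving beyond the scatter, although this single step cannot establish a pattern. No supporting information bears on this result. 

Going by these compounds, it remains open whether a longer acyl chain, such as propionyl or butyryl, on the same oxygen would also stay within the scatter of compound 2. On these data alone, it is equally open how an amine in place of the hydroxy group would read on the shared core, and whether either change would give a step beyond the scatter.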